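This account rests on a few compounds, and the source may have more. Where it says the series, first, only, none or still open, it means among the compounds named here.

Measured so far:
compound 1, `O=C(/C(=C\c1ccc(Cl)cc1Cl)S(=O)(=O)c1ccc(Br)cc1)c1ccc(Cl)cc1`: 50000 nM
compound 2, `O=C(/C(=C\c1ccc(Br)c(O)c1)Sc1ccc(Br)cc1)c1ccc(Br)cc1`: 1000 nM
compound 3, `O=C(/C(=C\c1ccc(F)cc1F)Sc1ccc(Br)cc1)c1ccc(Br)cc1`: 1000 nM

In a functional assay on DU-145 cells (Homo sapiens) for inhibition, read by trypan blue exclusion, with a stated time of 96 h (a higher number here means a weaker inhibitor of growth, a lower number a stronger inhibitor of growth), compound 1 gives 50000 nM, the highest number of the three; compound 2 with 1000 nM and compound 3 with 1000 nM both lie far lower, beyond the scatter, and within the scatter of each other.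

The step from compound 1 to compound 4, `O=C(/C(=C\c1c(O)cc(O)cc1O)S(=O)(=O)c1ccc(Br)cc1)c1ccc(Cl)cc1`, is 2,4,6-trihydroxyphenyl in place of 2,4-dichlorophenyl on a double-bonded chain carbon bound to a double-bonded chain carbon. Among the measured compounds shown here, compound 1 and compound 4 share a core that compound 2 and compound 3 do not have, so no measured step follows this change on the same core. For the measured compounds named here, the only measured step that bears on it is the one at the same place on the other core: no change at the digits printed from compound 2 to compound 3 (within the scatter). That step is small, but the groups exchanged there are nothing like the ones exchanged here, and compound 1 sits so high in this assay that the number may move either way or not at all. The working expectation is a modest move downward, with wide uncertainty, which gives an estimated step of a 2.5-fold lower number from compound 1 to compound 4 (0.40 log units; beyond the scatter).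

Compound 4 is therefore expected to give about 20000 nM in this assay, with a range from 3000 nM to 100000 nM.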

Compound 4, concentration for 50% growth inhibition: > 100000 nM
Compound 4 gave a limit, no number; the forecaster's own chance of this, stated with the estimate: 25%; at least 5.0-fold (0.69 log units) between middle value and limit.
By their numbers in this assay, from the lowest: compounds 2 and 3 (each within the scatter of the next); then compound 1. At a limit, above all of these: compound 4.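

In this assay compound 4 gives > 100000 nM, which is a limit of the assay and not a number: the limit of > 100000 nM in this assay, at which 1 of the 4 values shown sits.

Read as a step, this is an at least 2.0-fold higher number from compound 1 to compound 4 (0.30 log units; that floor lies within the scatter), so only a floor on the change is known, and the true size of the move stays unbounded upward. The earlier compounds shown here offered one step at this place, no change at the digits printed from compound 2 to compound 3 (within the scatter), and it lay on the other core; the new result adds that on the core of compound 1, 2,4,6-trihydroxyphenyl in place of 2,4-dichlorophenyl on a double-bonded chain carbon bound to a double-bonded chain carbon brings no lowering of the number in this assay, so this exchange gives no gain in growth inhibition on that core.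

Open, on these data alone, is how a 2,4,6-trimethoxyphenyl group or an aminophenyl group would read at this place on the core of compound 1, which would show whether the hydroxyl groups themselves matter. Also open, as far as these compounds go, is whether 2,4,6-trihydroxyphenyl would give a similar reading on the core of compound 2.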